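From Dimethoxypyridinyl to Pyridinyl: Expected Effect on Paw Edema

This account rests on a few compounds, and the source may have more. Where it says the series, first, only, none or still open, it means among the compounds named here.

Measured compounds:
- compound 1 `COc1ccnc(CNc2ccc3c(c2)nc(C)n3C[C@@H](O)[C@H]2O[C@H](O)[C@@H](O)[C@H]2O)c1OC`: 41%
- compound 2 `COc1ccnc(CNc2ccc3[nH]c(C)nc3c2)c1OC`: 15%
- compound 3 `Cc1nc2cc(NCc3ccccn3)ccc2[nH]1`: 10%

In a functional assay on the whole organism (strain Sprague-Dawley) for inhibition, with Rattus norvegicus as the target, read by paw edema, with a stated time of 180 min, at a dose of 10 mg/kg by the oral route (on this read-out lower numbers stand for a weaker effect and higher numbers for a stronger effect at the one dose given), compound 1 gives the highest of the three numbers, standing beyond the scatter above both compound 2 and compound 3. Among the compounds with values here, the one step told between measured compounds, a number 26 percentage points lower from compound 1 to compound 2 (beyond the scatter), concerns a hydrogen atom in place of a group of 11 heavy atoms on an aromatic nitrogen, a different place from the change now considered, so it bears on it only indirectly. Compound 4 `Cc1nc2cc(NCc3ccccn3)ccc2n1C[C@@H](O)[C@H]1O[C@H](O)[C@@H](O)[C@H]1O` differs from compound 1 by pyridin-2-yl in place of 3,4-dimethoxypyridin-2-yl on a saturated chain carbon bound to a nitrogen on an aromatic ring. Within the data shown here, no step is told for this change, but compound 2 gives 15% and compound 3 gives 10%, two values within the usual scatter of each other, and these two compounds differ in the same way. On that basis the step is expected to be small, a number 5 percentage points lower from compound 1 to compound 4 (within the scatter), likely within the scatter. Compound 4 is therefore estimated at 36%, with a range from 22% to 50%.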

Compound 4, a percentage reported as inhibition, in the whole organism at one dose (the size of the read-out at that dose, not a potency): 8%
For compound 4 the middle estimate is 28 percentage points above the measured one; the whole stated range lies above it.
By their numbers in this assay, from the lowest: compounds 4, 3 and 2 (each within the scatter of the next); then compound 1.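

In this assay the exchange of 3,4-dimethoxypyridin-2-yl for pyridin-2-yl, on a saturated chain carbon bound to a nitrogen on an aromatic ring, gives a number 33 percentage points lower from compound 1 to compound 4 (beyond the scatter) and so has a large effect when the group of compound 1 on the aromatic nitrogen is present. The same exchange separates compound 2 at 15% from compound 3 at 10% and these two values lie within the usual scatter of each other, so the exchange does not read the same in the two pairs. Nothing measured here accounts for this difference between the pairs.

Going by these compounds, whether a single methoxy group in place of the two would keep the value of compound 1 remains open. So does the effect of an ethoxy group or a chlorine atom on the same pyridine ring.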